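Chloro to fluoro on the pendant aryl: clearance expectation

The compounds below may be only part of what the source reports. "The series", "measured", "known", "first", "only" and "open" are said of these compounds alone.

Measured compounds in an ADME assay on microsomes from liver (Homo sapiens) for metabolic stability, tested at 2.5 uM; a higher number here means faster removal of the compound, a lower number slower removal:
compound 1 `O=S(=O)(c1cc(F)cc(F)c1)c1cnc2c(F)cccc2c1-c1cccc(Cl)c1`: 0.64 mL/min
compound 2 `COc1ccc(S(=O)(=O)c2cnc3c(F)cccc3c2-c2cccc(F)c2)cc1`: 3.03 mL/min
compound 3 `N#Cc1cccc(S(=O)(=O)c2cnc3c(F)cccc3c2-c2cccc(Cl)c2)c1`: 1.11 mL/min

Compound 3 holds the second highest of the three numbers in this assay. Its nearest neighbour is compound 1, and the move a 1.7-fold higher number from compound 1 to compound 3 (0.24 log units; within the scatter) stays within the scatter, so the two are not distinguishable on this read-out. Compound 2 sits furthest away, with a higher number than compound 3, and that gap is beyond the scatter.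

Compound 4 `N#Cc1cccc(S(=O)(=O)c2cnc3c(F)cccc3c2-c2cccc(F)c2)c1` is the next compound of the series, differing from compound 3 only by fluoro in place of chloro on an aromatic carbon.

For the measured compounds named here, no measured pair isolates this chloro-to-fluoro exchange. Compound 2 carries a fluorophenyl on the shared core and gives a higher number than compound 3, but compound 2 also differs at the aryl on the sulfonyl sulfur, so its value cannot be attributed to the halogen alone. Going by the values given here, the only single-point step recorded, a 1.7-fold higher number from compound 1 to compound 3 (0.24 log units; within the scatter), concerns the sulfonyl aryl and falls within the scatter.

On this basis no step beyond the scatter is expected, and the change for compound 4 is estimated as a 1.2-fold higher number from compound 3 to compound 4 (0.07 log units; within the scatter). Compound 4 is accordingly expected to give about 1.3 mL/min, with a range from 0.6 mL/min to 2.8 mL/min.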

Compound 4, intrinsic clearance in a liver preparation (reported as CLH), per the amount of preparation that the assay uses: 0.34 mL/min
Compound 4: middle estimate off by 3.8-fold (0.58 log units), on the high side; measured number below the stated range.
By their numbers in this assay, from the lowest: compounds 4, 1 and 3 (each within the scatter of the next, the first and the last beyond it); then compound 2.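

In this assay, for the compounds shown here, the exchange of 3-chlorophenyl for 3-fluorophenyl gives a 3.3-fold lower number from compound 3 to compound 4 (0.51 log units; beyond the scatter) and is the first single-place change at this aromatic carbon, showing that this halogen exchange alone can move the number beyond the scatter. With the 3-fluorophenyl held constant, the aryl on the sulfonyl sulfur also gives a step beyond the scatter, an 8.9-fold lower number from compound 2 to compound 4 (0.95 log units; beyond the scatter) for 3-cyanophenyl in place of 4-methoxyphenyl, which the earlier step at that place, within the scatter, did not show. No available evidence bears on why the number falls with either change.

Going by these compounds, the halogen exchange rests on one pair with 3-cyanophenyl on the sulfonyl sulfur, so it remains open whether a similar step would appear with another aryl there, such as 3,5-difluorophenyl or 4-methoxyphenyl. Also open, on these data alone, is how bromo, methyl or an amine on the same aromatic carbon would compare with chloro and fluoro in this read-out.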